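From pyrimidin-2-yl to butyl on a sulfur

The compounds below may be only part of what the source reports. "The series", "measured", "known", "first", "only" and "open" are said of these compounds alone.

- compound 1 `O=C(CSc1ncccn1)N1N=C(c2cc3ccccc3oc2=O)C[C@@H]1c1ccc(C(F)(F)F)cc1` with 4750 nM measured
- compound 2 `CC1=NN(C(=O)CSc2nc3ccccc3s2)[C@@H](c2cc(Br)cc(Br)c2O)C1` with 8700 nM measured

Both were measured in a functional assay on HepG2 cells (Homo sapiens) for cytotoxicity, read by MTT assay, with a stated time of 48 h (a lower number here means a stronger inhibitor, a higher number a weaker inhibitor), and their values lie within the scatter of each other, so compound 1 stands level with compound 2 on these numbers. Compound 3 `CCCCSCC(=O)N1N=C(c2cc3ccccc3oc2=O)C[C@@H]1c1ccc(C(F)(F)F)cc1` carries butyl in place of pyrimidin-2-yl on a sulfur. Among the compounds with values here, no measured pair shows such a change, so no step beyond the scatter is expected in this assay in either direction. The estimate therefore stays close to compound 1 at 4750 nM as its only anchor. The estimated change is a 1.1-fold higher number from compound 1 to compound 3 (0.02 log units; within the scatter) and no more. For compound 3 the estimated value is 5000 nM with an expected range of 1800 nM to 14000 nM when it is measured.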

Compound 3, half-maximal inhibitory concentration: 8680 nM
For compound 3 the middle estimate is 1.7-fold (0.24 log units) below the measured one, and the stated range covers the measured number.
By their numbers in this assay, from the lowest: compounds 1, 3 and 2 (each within the scatter of the next).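

In this assay, the first pair differing only on this sulfur gives a 1.8-fold higher number from compound 1 to compound 3 (0.26 log units; within the scatter). At this place, then, butyl, with no ring and 0 hydrogen-bond acceptors, stands level with pyrimidin-2-yl, a six-membered aromatic ring with 2 hydrogen-bond acceptors. No further measurement bears on this result.

From the compounds shown here alone, whether an amine, a carboxylic acid or a chain longer than butyl on this sulfur would give a step beyond the scatter remains open. So does whether a ring carrying no nitrogen would stand level here too.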